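This account rests on a few compounds, and the source may have more. Where it says the series, first, only, none or still open, it means among the compounds named here.

Measured compounds: compound 1 `COc1ccc(NS(=O)(=O)c2ccc(-c3ccccn3)s2)cc1N1C[C@@H](C)N[C@@H](C)C1` gives 15.9 nM in a functional assay for agonist activity at growth hormone secretagogue receptor type 1 (Homo sapiens), read by FLIPR; a lower number here means that less compound is needed, a higher number that more compound is needed for the effect; compound 2 `C[C@@H]1CN(c2cc(NS(=O)(=O)c3ccc(-c4ccccn4)s3)ccc2C#N)C[C@H](C)N1` gives 631 nM; compound 3 `CCOc1ccc(N2C[C@@H](C)N[C@@H](C)C2)cc1NS(=O)(=O)c1ccc(-c2ccccn2)s1` gives 39.8 nM.

Compound 3 stands second highest of these three numbers, with compound 1 nearest and compound 2 furthest. Compound 4 `C[C@@H]1CN(c2ccc(F)c(NS(=O)(=O)c3ccc(-c4ccccn4)s3)c2)C[C@H](C)N1` differs from compound 3 by fluoro in place of ethoxy on an aromatic carbon. No measured step removes an alkoxy group at exactly this place, but the only shown replacement of an alkoxy group, a 40-fold higher number from compound 1 to compound 2 (1.60 log units; beyond the scatter), was a large loss. A smaller but real loss in this assay is therefore expected for compound 4, giving a 2.8-fold higher number from compound 3 to compound 4 (0.44 log units; beyond the scatter). Compound 4 is estimated at 110 nM, within 30 nM to 400 nM.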

Compound 4, half-maximal effective concentration: 100 nM
Compound 4: the middle estimate sits 1.1-fold (0.04 log units) above what was measured; the range from low to high includes it.
By their numbers in this assay, from the lowest: compound 1; then compound 3; then compound 4; then compound 2.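

In this assay, replacing ethoxy with fluoro at this carbon, ortho to a large group and para to the 3,5-dimethylpiperazin-1-yl group, carries only a modest penalty: a 2.5-fold higher number from compound 3 to compound 4 (0.40 log units; beyond the scatter). This is a far smaller step than the only earlier one, a 40-fold higher number from compound 1 to compound 2 (1.60 log units; beyond the scatter), though that step involved different groups in a different arrangement on the ring. Nothing available explains the size of the new step. The compounds shown leave open how a longer chain such as propoxy, or an amine, would fare at this carbon.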